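The compounds below may be only part of what the source reports. "The series", "measured", "known", "first", "only" and "open" are said of these compounds alone.

Compound 1, `CCN(CC)CCCn1c(=O)c(=Cc2ccc(O)cc2)s/c1=C1\C(=O)Nc2ccc(C)cc21`, is the strongest of the three compounds measured in a functional assay on HT-29 cells (Homo sapiens) for inhibition, read by MTT assay, with a stated time of 72 h (on this read-out higher numbers stand for weaker inhibition and lower numbers for stronger inhibition), where compound 1 gives 770 nM. The nearest of the others is compound 3, `CN(C)CCn1c(=O)c(=Cc2ccc(O)cc2)s/c1=C1\C(=O)Nc2ccc(Cl)cc21`, which in this assay gives 2460 nM, a gap beyond the usual scatter. Furthest away is compound 2, `CN(C)CCN1C(=O)/C(=C/c2ccc(O)cc2)SC1=S`, which lacks the fused bicyclic portion shared by the other two; in this assay compound 2 gives 59700 nM.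

Compound 4, `CCN(CC)CCCn1c(=O)c(=Cc2ccccc2O)s/c1=C1\C(=O)Nc2ccc(C)cc21`, has not yet been measured. It differs from compound 1 in one place: 2-hydroxyphenyl in place of 4-hydroxyphenyl on a double-bonded chain carbon bound to an aromatic carbon. No measured pair among these three compounds shows this same change, so there is no step on which to lean directly. The three measured compounds do show that the hydroxyphenyl-bearing exocyclic position tolerates variation elsewhere in the molecule while keeping sub-micromolar to low-micromolar activity. A modest weakening beyond the scatter is expected for the step of a 2.3-fold higher number from compound 1 to compound 4 (0.37 log units; beyond the scatter). Compound 4 is therefore estimated to give 1800 nM in this assay, within a range from 600 nM to 5500 nM.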

Compound 4, half-maximal inhibitory concentration: 8070 nM
Beside the measured number, compound 4's estimate is 4.5-fold (0.65 log units) below it; measured number above the stated range.
By their numbers in this assay, from the lowest: compound 1; then compound 3; then compound 4; then compound 2.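

In this assay, 2-hydroxyphenyl in place of 4-hydroxyphenyl on a double-bonded chain carbon bound to an aromatic carbon gives a 10-fold higher number from compound 1 to compound 4 (1.02 log units; beyond the scatter), a large step beyond the scatter. For the compounds shown here, the two groups have the same atoms and the same counts of donors and acceptors, so this position responds strongly to how the hydroxyphenyl is joined, which the earlier compounds could not show, as all three carry 4-hydroxyphenyl. Nothing available explains this loss of inhibition.

The compounds shown leave open whether a plain phenyl or a 4-methoxyphenyl group at this position would stay close to compound 1 or fall towards compound 4. They also leave open whether the step would keep its size on another background, since it is seen only once.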